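The source may report more compounds than this note shows. Statements on the series, on what has been measured and on what is new or still open speak of the compounds shown alone.

In a functional assay on HeLa cells (Homo sapiens) for cytotoxicity, read by ELISA, with a stated time of 4 days (a lower number here means a stronger inhibitor, a higher number a weaker inhibitor), compound 1 `Clc1ccc(-c2cc(-c3ccco3)cc(-c3ccc(Cl)s3)n2)cc1` gives 17000 nM and compound 2 `Clc1ccc(-c2cc(-c3ccoc3)cc(-c3ccco3)n2)s1` gives 22700 nM, so the two values lie within the scatter of each other. Compound 3 `Cc1ccc(-c2cc(-c3ccoc3)cc(-c3ccc(Cl)s3)n2)cc1` has 4-methylphenyl in place of furan-2-yl on an aromatic carbon of compound 2: 4-methylphenyl in place of furan-2-yl on an aromatic carbon. Going by the values given here, no measured pair isolates a change of this kind, so the size of the step remains open. The expected step, a 1.5-fold lower number from compound 2 to compound 3 (0.18 log units; within the scatter), stays within the scatter and has no firm direction. For compound 3 the estimated value in this assay is 15000 nM, with an expected range of 6000 nM to 35000 nM.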

Compound 3, half-maximal inhibitory concentration: 28700 nM
The estimate for compound 3 lay 1.9-fold (0.28 log units) below the measured number; the measured number falls inside the stated range.
By their numbers in this assay, from the lowest: compounds 1, 2 and 3 (each within the scatter of the next).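

On the aromatic carbon next to the ring nitrogen, 4-methylphenyl in place of furan-2-yl gives a 1.3-fold higher number from compound 2 to compound 3 (0.10 log units; within the scatter) in this assay, so this position tolerates one six-membered aromatic ring of carbon only as well as a five-membered one with a hetero atom. The hydrogen-bond acceptor counted on furan-2-yl makes no difference beyond the scatter here. Nothing measured bears on the reason for this result. As far as these compounds go, whether an amine or a carboxylic acid on this ring position would move the number beyond the scatter stays open. So does whether the same exchange behaves alike without the 5-chlorothiophen-2-yl group.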